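A few compounds are considered here, and "the series" means these few. Any claim that something is new, unique, unknown or untested is made for them only; others in the source may bear on it.

Two amides sharing one core have been tested in a functional assay on the whole organism (strain Wistar) for inhibition, with Rattus norvegicus as the target, read by paw edema, with stated times of 60 min and 6 h, at a dose of 100 mg/kg by the oral route; a higher number here means more inhibition at the dose given (going by the name of the read-out), a lower number less inhibition. Compound 1 `CNC(=O)CC1CCc2cc(OC)c(OC)cc21` carries a methylamino group on the carbonyl carbon, and in this assay compound 1 gives 24.1%. Compound 2 `CCN(CC)C(=O)CC1CCc2cc(OC)c(OC)cc21` carries a diethylamino group in the same place, and in this assay compound 2 gives 31.5%. Among the compounds with values here, the one step between them, a number 7.4 percentage points higher from compound 1 to compound 2 (within the scatter), is the only comparison available, and it does not separate the two compounds: compound 2 stands at the top of the two numbers only by that step, which lies within the scatter.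

Compound 3 `COc1cc2c(cc1OC)C(CC(=O)NC(C)C)CC2` has not yet been measured. Its change from compound 2 is isopropylamino in place of diethylamino on a carbonyl carbon. Within the data shown here, the one measured step that bears on this is the change on the carbonyl carbon from compound 1 to compound 2, which was a number 7.4 percentage points higher from compound 1 to compound 2 (within the scatter), within the scatter. Compound 3 is therefore expected to move by no more than the scatter, with an estimated step of a number 3.5 percentage points lower from compound 2 to compound 3 (within the scatter). Compound 3 is estimated to give 28% in this assay, within a range from 14% to 42%.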

Compound 3, a percentage reported as inhibition, in the whole organism at one dose (the size of the read-out at that dose, not a potency): 37%
Compound 3: the middle estimate sits 9 percentage points below what was measured, within the range that was stated.
By their numbers in this assay, from the lowest: compounds 1, 2 and 3 (each within the scatter of the next, the first and the last beyond it).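

In this assay, the position on the carbonyl carbon now shows its first change beyond the scatter: isopropyl in place of methyl on the amide-type nitrogen gives a number 12.9 percentage points higher from compound 1 to compound 3 (beyond the scatter) and thus separates compound 3 from compound 1, which the earlier pair of compounds could not do for any group. The exchange of diethylamino for isopropylamino removes one carbon from the group and brings 1 hydrogen-bond donor where diethylamino has 0, yet it gives a number 5.5 percentage points higher from compound 2 to compound 3 (within the scatter) and so does not separate these two amides, which means that the data cannot tie the response to the amide hydrogen or to the size of the group. Nothing available offers an explanation for either step.

The compounds shown leave open whether the response continues to follow the group on the amide nitrogen with a tert-butylamino or cyclohexylamino group in this place. They also leave open how a dimethylamino group, which pairs a small group with no amide hydrogen, or a carboxylic acid in place of the amide would compare on the same core.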